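Boronic acid series: amide cap change from compound 1

A few compounds are considered here, and "the series" means these few. Any claim that something is new, unique, unknown or untested is made for them only; others in the source may bear on it.

Going by the values given here, compound 1 `CCC[C@@H](NC(=O)c1cnccn1)C(=O)N[C@@H](CCCc1ccccc1)B(O)O` gives the lowest number of the two measured so far in an assay on isolated protein for inhibition of Lon protease homolog, mitochondrial (Homo sapiens), read by HTRF, with a stated time of 50 min, in the presence of a further agent that is not named here (a lower number here means a stronger inhibitor, a higher number a weaker inhibitor), at 17 nM. Its nearest neighbour is compound 2 `CCC[C@@H](NC(=O)c1cnccn1)C(=O)N[C@@H](CCc1ccccc1)B(O)O`, which in this assay gives 92 nM; the step of a 5.4-fold higher number from compound 1 to compound 2 (0.73 log units; beyond the scatter) arises from phenyl in place of benzyl on a saturated chain carbon, three bonds along the chain from an amide-type nitrogen and a boron atom.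

Compound 3 `CCC[C@@H](NC(=O)c1oc(C)nc1C)C(=O)N[C@@H](CCCc1ccccc1)B(O)O` differs from compound 1 at the other end of the molecule: 2,4-dimethyl-1,3-oxazol-5-yl in place of pyrazin-2-yl on a carbonyl carbon. Among the compounds with values here, no measured step touches the carbonyl cap, so the single step recorded, which concerns the chain next to the boron atom, does not bear on this change. With nothing to anchor direction, the expected step of a 1.5-fold higher number from compound 1 to compound 3 (0.17 log units; within the scatter) is no change beyond the scatter, with wide uncertainty on either side. Compound 3 is therefore estimated at 25 nM in this assay, within a range of 6 nM to 110 nM.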

Compound 3, half-maximal inhibitory concentration: 59 nM
Compound 3: the middle estimate sits 2.4-fold (0.37 log units) below what was measured; the range from low to high includes it.
By their numbers in this assay, from the lowest: compound 1; then compounds 3 and 2 (each within the scatter of the next).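

In this assay the carbonyl cap counts as well as the chain: 2,4-dimethyl-1,3-oxazol-5-yl in place of pyrazin-2-yl on a carbonyl carbon gives a 3.5-fold higher number from compound 1 to compound 3 (0.54 log units; beyond the scatter) and so moves the number beyond the scatter at this end of the molecule. Both ends of the shared core now respond to change, and of the two caps on this core, pyrazin-2-yl gives the lower number. No measurement at hand accounts for this step.

The swap alters the ring size, the hetero atoms and the methyl groups at once, so which of these carries the step stays unresolved; the plain 1,3-oxazol-5-yl or pyridin-2-yl would help separate them. Also open, as far as these compounds go, is whether the cap step carries over to the shorter chain of compound 2.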